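Ether-linked acetylpiperidine in place of amide-linked acetylpiperazine

The compounds below may be only part of what the source reports. "The series", "measured", "known", "first", "only" and "open" are said of these compounds alone.

Measured so far:
compound 1 `COc1ncc(N2CCc3ncnc(O[C@H]4CCN(C(=O)C5CCOCC5)C4)c3C2)cc1C(F)(F)F`: 3580 nM
compound 2 `COc1ccc(N2CCc3ncnc(-c4cccc(C(=O)N5CCN(C(C)=O)CC5)c4)c3C2)cn1`: > 10000 nM
compound 3 `CCC(=O)N1CC[C@H](Oc2ncnc3c2CN(c2ccc(OC)nc2)CC3)C1`: > 10000 nM

In an ADME assay on Rat1 cells for inhibition of phosphatidylinositol 4,5-bisphosphate 3-kinase catalytic subunit beta isoform (Homo sapiens), with a stated time of 1 h (on this read-out lower numbers stand for stronger inhibition and higher numbers for weaker inhibition), compound 1 gives 3580 nM. Compound 2 returns only a limit, > 10000 nM. Compound 3 likewise returns only a limit, > 10000 nM. Compound 2 thus sits at the limit of > 10000 nM in this assay, at which 2 of the 3 values shown sit, and has no number of its own, so its place among the three cannot be fixed more closely. Going by the values given here, no pair of measured compounds differs in a single place, so there is no measured step to lean on.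

Compound 4 `COc1ccc(N2CCc3ncnc(-c4cccc(OC5CCN(C(C)=O)CC5)c4)c3C2)cn1` differs from compound 2 in one place: (1-acetylpiperidin-4-yl)oxy in place of (4-acetylpiperazin-1-yl)carbonyl on an aromatic carbon. The acetylated saturated ring stays; the carbonyl link gives way to an ether link. With compound 2 at the limit, only a gain could appear as a number. Compound 1 carries an ether-linked acetyl-free ring on the shared core and gives 3580 nM, but it is not a single-place neighbour of this pair.

The step from compound 2 to compound 4 is expected to be an at least 1.1-fold lower number from compound 2 to compound 4 (0.04 log units; that floor lies within the scatter), that is, nothing clearly beyond the scatter. Compound 4 is therefore estimated at 9000 nM, within 3000 nM to 30000 nM, with a real chance of another limit.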

Compound 4, half-maximal inhibitory concentration: > 10000 nM
Compound 4: a limit, no number; the forecaster's own chance of this, stated with the estimate: 55%; at least 1.1-fold (0.04 log units) between middle value and limit.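

Compound 2 and compound 4 each return only a limit, and no step between them can be read because neither has a number of its own: the limit of > 10000 nM in this assay, at which 3 of the 4 values shown sit.

Whether (1-acetylpiperidin-4-yl)oxy in place of (4-acetylpiperazin-1-yl)carbonyl changes inhibition at all stays open, since the compounds shown give no number on either side of this change.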